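The source may hold more compounds than are shown below. What is called first, only, known or untested is meant among the compounds shown, and "the series" means these compounds.

Measured so far:
- compound 1, `Cc1nc2c3ccccc3ccc2c2nc3c(ccc4ccccc43)c(-c3cccc([N+](=O)[O-])c3)c12`, gives 54.2 ug/mL in a functional assay, read by spectrophotometry, with a stated time of 15 min; on this read-out higher numbers stand for weaker inhibition and lower numbers for stronger inhibition
- compound 2, `Cc1nc2c3ccccc3ccc2c2nc3c(ccc4ccccc43)c(-c3ccccc3N)c12`, gives 45.6 ug/mL in this assay

Among the measured compounds shown here, compound 2 holds the lower of the two numbers, but the only measured step, a 1.2-fold lower number from compound 1 to compound 2 (0.08 log units; within the scatter), stays within the scatter, so the two compounds cannot be told apart on these data. Compound 3, `Cc1nc2c3ccccc3ccc2c2nc3c(ccc4ccccc43)c(-c3ccccc3Cl)c12`, has not been measured yet. It differs from compound 2 by chloro in place of amino on an aromatic carbon. For the measured compounds named here, only one measured step exists to lean on, a 1.2-fold lower number from compound 1 to compound 2 (0.08 log units; within the scatter), and it swapped a whole substituted phenyl for another on the shared core rather than exchanging one small group for another at the same place, so it bears on the present change only loosely. There is no measured exchange of an amino for a chloro anywhere here. With nothing pointing either way, the expected step is a 1.0-fold lower number from compound 2 to compound 3 (0.01 log units; within the scatter), that is, no movement beyond the scatter. Compound 3 is therefore estimated at 45 ug/mL in this assay, with a range from 20 ug/mL to 100 ug/mL.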

Compound 3, half-maximal inhibitory concentration: 74.6 ug/mL
Estimate against measurement, compound 3: 1.7-fold (0.22 log units) below; low and high end bracket the measured number.
By their numbers in this assay, from the lowest: compounds 2, 1 and 3 (each within the scatter of the next).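

Among the compounds shown here, this is the first exchange of one small group for another at the same place: on an aromatic carbon ortho to a large group, chloro in place of amino gives a 1.6-fold higher number from compound 2 to compound 3 (0.21 log units; within the scatter) in this assay, so removing the hydrogen-bond donor and acceptor counted on amino does not separate these two compounds on this read-out. The other new comparison alters both the group and where it sits on the phenyl ring, and 2-chlorophenyl in place of 3-nitrophenyl gives a 1.4-fold higher number from compound 1 to compound 3 (0.14 log units; within the scatter) as the measured result, which also stays inside the scatter. With amino, chloro and nitro substituents, all three compounds therefore remain indistinguishable here, and nothing available explains the small differences among their numbers.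

Still open, on these data alone, is whether any group on this phenyl ring can move the number beyond the scatter, for example a carboxylic acid, a methoxy group or a longer alkyl chain, or whether a plain phenyl with no substituent would read the same. Also open, as far as these compounds go, is whether chloro and amino would stay indistinguishable on a different part of the shared core.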